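A few compounds are considered here, and "the series" means these few. Any claim that something is new, unique, unknown or untested is made for them only; others in the source may bear on it.

Compound 1 `CC1=C(/C=C/C(C)=C/C=C/C(C)=C\C(=O)Nc2ccccc2)C(C)(C)CCC1n1ccnc1` gives 1730 nM in a functional assay on SK-BR-3 cells (Homo sapiens) for inhibition, read by MTT assay (on this read-out higher numbers stand for weaker inhibition of growth and lower numbers for stronger inhibition of growth), the lowest of the three numbers shown; compound 2 `CC1=C(/C=C/C(C)=C/C=C/C(C)=C\C(=O)NCc2cccc(F)c2)C(C)(C)CCC1n1ccnc1` gives 4240 nM and compound 3 `CC1=C(/C=C/C(C)=C/C=C/C(C)=C\C(=O)Nc2cccc(F)c2)C(C)(C)CCC1n1ccnc1` gives 17000 nM. Compound 4 `CC1=C(/C=C/C(C)=C/C=C/C(C)=C\C(=O)NCc2ccc(F)cc2)C(C)(C)CCC1n1ccnc1` differs from compound 1 by 4-fluorobenzyl in place of phenyl on an amide-type nitrogen. The step that bears most directly on this is a 2.5-fold higher number from compound 1 to compound 2 (0.39 log units; beyond the scatter), since it also exchanges phenyl for a fluorinated benzyl group; the other steps, a 9.8-fold higher number from compound 1 to compound 3 (0.99 log units; beyond the scatter) and a 4.0-fold higher number from compound 2 to compound 3 (0.60 log units; beyond the scatter), both run toward weaker inhibition of growth. A modest rise in the number is therefore expected for compound 4 in this assay, about a 2.3-fold higher number from compound 1 to compound 4 (0.36 log units; beyond the scatter). Compound 4 is estimated at 4000 nM, within a range from 1700 nM to 10000 nM.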

Compound 4, concentration for 50% growth inhibition: 5500 nM
Beside the measured number, compound 4's estimate is 1.4-fold (0.14 log units) below it; low and high end bracket the measured number.
By their numbers in this assay, from the lowest: compound 1; then compounds 2 and 4 (each within the scatter of the next); then compound 3.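

In this assay, 4-fluorobenzyl on the amide-type nitrogen gives a 3.2-fold higher number from compound 1 to compound 4 (0.50 log units; beyond the scatter), so a second fluorinated benzyl group also falls on the weaker side of the plain phenyl of compound 1. Moving the fluoro on the benzyl ring changes little, with a 1.3-fold higher number from compound 2 to compound 4 (0.11 log units; within the scatter), while a 3.1-fold lower number from compound 3 to compound 4 (0.49 log units; beyond the scatter) shows that this benzyl amide stays clearly apart from the 3-fluorophenyl amide. Nothing shown explains these differences.
Open, from the compounds shown here alone, is how unsubstituted benzyl on this nitrogen would compare, which would separate the added carbon from the fluoro. Also open, going by these compounds, is whether a longer chain such as 2-phenylethyl would match compound 1.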